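A few compounds are considered here, and "the series" means these few. Any claim that something is new, unique, unknown or untested is made for them only; others in the source may bear on it.

Compound 1, `CCCCCOc1cccc2ccc(N)nc12`, gives 580 nM in an assay on cells with melanin-concentrating hormone receptor 1 (Homo sapiens) as the target, read by radioligand binding; a lower number here means a stronger inhibitor, a higher number a weaker inhibitor.
Compound 2, `CCCOc1cccc2ccc(N)nc12`, gives 1100 nM in this assay.
Compound 3, `Nc1ccc2cccc(OCCC3CC3)c2n1`, gives 492 nM in this assay.

All three share one core and differ only in the chain attached to the oxygen on the aromatic ring. Compound 3 has the lowest number of the three, yet its gap to compound 1 is within the scatter and only its gap to compound 2 is beyond it, so it cannot be called the strongest. Among the compounds with values here, the steps so far are small: a 1.9-fold higher number from compound 1 to compound 2 (0.28 log units; within the scatter), a 1.2-fold lower number from compound 1 to compound 3 (0.07 log units; within the scatter) and a 2.2-fold lower number from compound 2 to compound 3 (0.35 log units; beyond the scatter).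

Compound 4, `CCOCC(C)Oc1cccc2ccc(N)nc12`, has not been measured. The change from compound 3 is a group of 6 heavy atoms (5 carbon, 1 oxygen; no ring) in place of a group of 5 heavy atoms (5 carbon; one three-membered non-aromatic ring of carbon only), on an oxygen on an aromatic ring. The measured steps bear on it only loosely, since none of them introduces an oxygen into the chain; they show that reshaping the chain moved this assay by at most a modest amount. A similarly small shift, or none beyond the scatter, is expected. Compound 4 is therefore estimated at 800 nM, with a range from 300 nM to 2500 nM. This estimate corresponds to an expected step of a 1.6-fold higher number from compound 3 to compound 4 (0.21 log units; within the scatter).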

Compound 4, half-maximal inhibitory concentration: 1070 nM
Compound 4: middle estimate off by 1.3-fold (0.13 log units), on the low side; the measured number falls inside the stated range.
By their numbers in this assay, from the lowest: compounds 3, 1, 4 and 2 (each within the scatter of the next, the first and the last beyond it).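

Within the data shown here, compound 4 is the first compound here whose chain carries an oxygen and so a hydrogen-bond acceptor, and in this assay exchanging the 2-cyclopropylethyl group for this chain gives a step beyond the scatter (a 2.2-fold higher number from compound 3 to compound 4 (0.34 log units; beyond the scatter)). The oxygen-bearing chain does not separate from either plain chain, as both steps lie within the scatter (a 1.0-fold lower number from compound 2 to compound 4 (0.01 log units; within the scatter); a 1.8-fold higher number from compound 1 to compound 4 (0.27 log units; within the scatter)), so it shows no gain over them. No measurement available here explains these steps.

Compound 4 differs from the others in more than its oxygen, so the part played by the oxygen alone stays unresolved. As far as these compounds go, it is also open how this assay would respond to an amine in the chain or to a longer chain ending in a cyclopropyl ring.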